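The source may report more compounds than this note shows. Statements on the series, on what has been measured and on what is new or still open speak of the compounds shown alone.

Working notes on the series. Compound 1 `CCOC(=O)c1c(-c2cccc(OC)c2)[nH]c2cc(OC)c(OC)cc2c1=O` carries two methoxy groups on the shared core; compound 2 `CCOC(=O)c1c(-c2cccc(OC)c2)[nH]c2cc(OC)c(Cl)cc2c1=O` and compound 3 `CCOC(=O)c1c(-c2cccc(OC)c2)[nH]c2cc(OC)c(F)cc2c1=O` replace one of them with chloro and with fluoro. In an ADME assay on HEK293 cells (Homo sapiens) for cytotoxicity, read by luminescence, with a stated time of 72 h (a lower number here means that less compound is needed, a higher number that more compound is needed for the effect), compound 1 gives only a limit, > 22000 nM. In this assay compound 2 likewise gives only a limit, > 22000 nM. In this assay compound 3 also gives only a limit, > 22000 nM. Compound 3 thus stands at the same limit as the other two, and no number is known for any of them. The steps a step that the two limits leave unreadable from compound 1 to compound 2, a step that the two limits leave unreadable from compound 1 to compound 3 and a step that the two limits leave unreadable from compound 2 to compound 3 are not readable because of the limit of > 22000 nM in this assay, at which 3 of the 3 values shown sit.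

Compound 4 `CCOC(=O)c1c(-c2cccc(F)c2)[nH]c2cc(OC)c(F)cc2c1=O` differs from compound 3 by fluoro in place of methoxy on an aromatic carbon, that is, 3-methoxyphenyl to 3-fluorophenyl. Among the compounds with values here, none of the measured steps concerns this change, and all of them are unreadable in any case, so they give no direction. In this assay the expected step is a number no higher from compound 3 to compound 4 (the limit leaves the size open), none beyond the scatter. Compound 4 is expected to give 22000 nM in this assay. For compound 4 the expected range runs from 8000 nM to 60000 nM, most likely again only a limit.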

Compound 4, half-maximal effective concentration: > 22000 nM
Compound 4 ended at the assay's limit; the forecaster's own chance of this, stated with the estimate: 85%; the middle value sits exactly at the limit.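

The step from compound 3 to compound 4 cannot be read, because both compounds give only a limit and no number: the limit of > 22000 nM in this assay, at which 4 of the 4 values shown sit.

The compounds shown leave open how much of any of them is needed for the effect in this assay, and whether any change on the shared core shifts that amount.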